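Phenyl in Place of Methyl: What Compound 4 Should Show

The compounds below may be only part of what the source reports. "The series", "measured", "known", "first", "only" and "open" are said of these compounds alone.

compound 1 `CCOC(=O)c1nn(-c2ccccc2)c(-c2ccc(OC)cc2OC)c1-c1ccccc1` — 20.2%
compound 2 `CCOC(=O)c1nn(-c2ccccc2)c(-c2ccc(OC)cc2OC)c1C` — 5.77%
compound 3 `CCOC(=O)c1nn(-c2ccc(Cl)cc2)c(-c2ccc(OC)cc2OC)c1C` — 2.38%

In a functional assay on the whole organism (strain albino) for inhibition, with Rattus norvegicus as the target, read by paw edema, with stated times of 30 min and 4 h, at a dose of 25 mg/kg by the intraperitoneal route (on this read-out lower numbers stand for less inhibition and higher numbers for more inhibition at the one dose given (going by the name of the read-out)), compound 3 stands lowest of the three numbers. Its nearest neighbour is compound 2, and the step of a number 3.4 percentage points lower from compound 2 to compound 3 (within the scatter) lies within the scatter, so no order between these two can be claimed; compound 1 stands well beyond the scatter above compound 3.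

Compound 4 `CCOC(=O)c1nn(-c2ccc(Cl)cc2)c(-c2ccc(OC)cc2OC)c1-c1ccccc1` differs from compound 3 by phenyl in place of methyl on an aromatic carbon. For the measured compounds named here, the one step that bears on this is a number 14.4 percentage points lower from compound 1 to compound 2 (beyond the scatter), the same change run in the opposite direction. Reversing it, a rise of similar size is expected, a number 14.6 percentage points higher from compound 3 to compound 4 (beyond the scatter). The estimate for compound 4 is therefore 17%, with a range from 6% to 30%.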

Compound 4, a percentage reported as inhibition, in the whole organism at one dose (the size of the read-out at that dose, not a potency): 15.4%
Estimate against measurement, compound 4: 1.6 percentage points above; low and high end bracket the measured number.
By their numbers in this assay, from the lowest: compounds 3, 2, 4 and 1 (each within the scatter of the next, the first and the last beyond it).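

In this assay, phenyl in place of methyl gives a number 13 percentage points higher from compound 3 to compound 4 (beyond the scatter), so the gain from phenyl at this position is now seen with a 4-chlorophenyl group on the ring nitrogen as well, at much the same size: the same change on two cores in this assay, a number 14.4 percentage points lower (beyond the scatter) from compound 1 to compound 2 and a number 13 percentage points lower (beyond the scatter) from compound 4 to compound 3, 1.4 percentage points apart, within the scatter of two such steps Chloro in place of hydrogen gives a number 4.8 percentage points lower from compound 1 to compound 4 (within the scatter), so with phenyl at this position, as with methyl, the chloro change cannot be told from no change: the same change on two cores in this assay, a number 3.4 percentage points lower (within the scatter) from compound 2 to compound 3 and a number 4.8 percentage points lower (within the scatter) from compound 1 to compound 4, 1.4 percentage points apart, within the scatter of two such steps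

The compounds shown leave open whether another group on this carbon, such as ethyl, cyclohexyl or an amine, would match phenyl. They also do not tell whether a substituted phenyl would differ from plain phenyl here.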